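A few compounds are considered here, and "the series" means these few. Any claim that something is new, unique, unknown or untested is made for them only; others in the source may bear on it.

Measured compounds in a toxicity assay on GES1 cells (Homo sapiens) for inhibition, read by MTT assay, with a stated time of 72 h; a lower number here means a stronger inhibitor, a higher number a weaker inhibitor:

compound 1 `Cc1cc(N2CC[C@@H](C)[C@@H](N(C)c3ncnc4[nH]ccc34)C2)n2nc(SCC3CCCCC3)nc2n1` gives 98200 nM.
compound 2 `C[C@@H]1CCN(c2cc(-c3ccccc3)nc3ncnn23)C[C@@H]1N(C)c1ncnc2[nH]ccc12` reaches only the limit > 100000 nM.
compound 3 `CCc1cc(N2CC[C@@H](C)[C@@H](N(C)c3ncnc4[nH]ccc34)C2)n2ncnc2n1` reaches only the limit > 100000 nM.

Within the data shown here, compound 1 is thus the one compound with a number in this assay; the other two sit at the limit (the limit of > 100000 nM in this assay, at which 2 of the 3 values shown sit). Among the measured compounds shown here, the single measured step, a step that the two limits leave unreadable from compound 2 to compound 3, runs between two limits and cannot be read for size.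

Compound 4 `Cc1cc(N2CC[C@@H](C)[C@@H](N(C)c3ncnc4[nH]ccc34)C2)n2nc(SCc3cc(Cl)ccc3Cl)nc2n1` differs from compound 1 in one place: 2,5-dichlorophenyl in place of cyclohexyl on a saturated chain carbon bound to a sulfur. For the measured compounds named here, no measured step touches this part of the core, so nothing here points to a change in either direction. Compound 4 is therefore expected to sit close to compound 1, at about 100000 nM (range 40000 nM to 250000 nM), a step of a 1.0-fold higher number from compound 1 to compound 4 (0.01 log units; within the scatter) that is expected to stay within the scatter.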

Compound 4, half-maximal inhibitory concentration: 87500 nM
Compound 4: middle estimate off by 1.1-fold (0.06 log units), on the high side, and the stated range covers the measured number.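

In this assay, among these compounds, the exchange of 2,5-dichlorophenyl for cyclohexyl on a saturated chain carbon bound to a sulfur gives the first step that can be read: a 1.1-fold lower number from compound 1 to compound 4 (0.05 log units; within the scatter). At this place, then, the non-aromatic carbon ring and the chlorinated aromatic ring cannot be told apart in this assay. Compound 2 and compound 3 give no number to compare with, only a limit: the limit of > 100000 nM in this assay, at which 2 of the 4 values shown sit.

Still open, on these data alone, is whether an amine or a carboxylic acid in place of the ring would give a step beyond the scatter. The same holds for a longer chain at this place.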